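Bromo substitution on the benzoxazine-type ring of compound 1

This account rests on a few compounds, and the source may have more. Where it says the series, first, only, none or still open, it means among the compounds named here.

Compound 1, `O=c1cc(-c2ccccc2)oc2ccc(N3COc4ccccc4C3)cc12`, is the reference point of this small series. Among the measured compounds shown here, in a functional assay on MCF7 cells (Homo sapiens) for inhibition, read by MTT assay, with a stated time of 48 h, tested at 7.5 ug/mL (on this read-out higher numbers stand for more inhibition of growth at the one concentration tested and lower numbers for less inhibition of growth), compound 1 gives 8.7%, the lowest of the three numbers measured so far. Compound 2, `COc1cc2c(c(OC)c1)OCN(c1ccc3c(=O)cc(-c4ccccc4)oc3c1)C2`, gives 45.8% in this assay, and compound 3, `Cc1cccc2c1OCN(c1ccc3c(=O)cc(-c4ccccc4)oc3c1)C2`, gives 43.9%; both lie beyond the scatter above compound 1, while the gap between compound 2 and compound 3 is within it. Both higher numbers come from compounds carrying substituents on the aromatic ring of the ring-fused part attached to the nitrogen, whereas compound 1 has that ring unsubstituted.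

Compound 4, `O=c1cc(-c2ccccc2)oc2ccc(N3COc4c(Br)cccc4C3)cc12`, is not yet measured. It differs from compound 1 by one change: bromo in place of hydrogen on an aromatic carbon. For the measured compounds named here, no measured pair in this assay carries exactly this change, so the size of the step is open. Going by the values given here, the only guidance is that substitution on this ring, as in compound 3 with 43.9% against compound 1 with 8.7%, has gone with a clearly higher number.

Compound 4 is therefore expected to sit above compound 1, with a step of a number 24.3 percentage points higher from compound 1 to compound 4 (beyond the scatter) estimated. The estimate for compound 4 in this assay is 33%, with a range from 10% to 55%.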

Compound 4, percent growth inhibition at one concentration: "not active" (no number reported)
Compound 4 has no reported number here; no gap can be computed for the estimate.
By their numbers in this assay, from the lowest: compound 1; then compounds 3 and 2 (each within the scatter of the next).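

In this assay, among the compounds shown here, compound 4 is reported as "not active" (no number reported) without a number, so no step from compound 1 to compound 4 can be read. No supporting data bearing on this result are available. The compounds shown leave open how large any change in growth inhibition from bromo in place of hydrogen is.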